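Methyl on the Ring Nitrogen: Expected Half-Life of Compound 3

The source may report more compounds than this note shows. Statements on the series, on what has been measured and on what is new or still open speak of the compounds shown alone.

Measured compounds:
- compound 1, `OC(c1nc2cc(Cl)c(Cl)cc2[nH]1)C(F)(F)F`, 14.7 h
- compound 2, `CC(C)(O)c1nc2cc(Cl)c(Cl)cc2[nH]1`, 4 h

Both compounds were tested in an in vivo ADME assay on the whole organism (strain Sprague-Dawley) for metabolic stability, with Rattus norvegicus as the target; a lower number here means that the compound disappears faster, a higher number that the compound lasts longer. Compound 1 gives 14.7 h, while compound 2 gives 4 h, the lowest of the two numbers; the gap between the two values lies beyond the usual scatter. Compound 3, `Cn1c(C(C)(C)O)nc2cc(Cl)c(Cl)cc21`, has not yet been measured. It differs from compound 2 by one change: methyl in place of hydrogen on an aromatic nitrogen. Within the data shown here, no measured pair shows the effect of this particular change, so its size in this assay cannot be read from the data. Only a modest shift is expected, from compound 2 to compound 3 amounting to a 1.3-fold higher number from compound 2 to compound 3 (0.10 log units; within the scatter). Compound 3 is therefore estimated at 5 h in this assay, with a range from 2 h to 12 h.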

Compound 3, half-life: 3 h
Beside the measured number, compound 3's estimate is 1.7-fold (0.22 log units) above it; the range from low to high includes it.
By their numbers in this assay, from the lowest: compounds 3 and 2 (each within the scatter of the next); then compound 1.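

In this assay, the single-change pair gives a 1.3-fold lower number from compound 2 to compound 3 (0.12 log units; within the scatter) for methyl in place of hydrogen on an aromatic nitrogen. Among these compounds, this is the first direct reading at this position, next to the ring atom that bears a 1-hydroxy-1-methylethyl group, and the step stays within the scatter. For this pair, then, the hydrogen on the ring nitrogen can be replaced by methyl with no shift beyond the scatter in the half-life, and nothing available here gives a reason for this result.

The compounds shown leave open whether a longer chain, such as ethyl, or a chain ending in an amine or a carboxylic acid would behave like methyl on this nitrogen. They also leave open whether the same methyl on compound 1 would give a step of similar size.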